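Aryl swap on the aromatic nitrogen: compound 3 to compound 4

A few compounds are considered here, and "the series" means these few. Any claim that something is new, unique, unknown or untested is made for them only; others in the source may bear on it.

Measured so far in a functional assay on MCF7 cells (Homo sapiens) for antiproliferative activity, read by MTT assay, with a stated time of 48 h; on this read-out lower numbers stand for stronger inhibition and higher numbers for weaker inhibition:
- compound 1 `N#CC1=C(N)Oc2c(c3nc4ccccc4nc3c3ccccc23)C12C(=O)N(Cc1cnnn1-c1ccc(Br)cc1)c1ccccc12`: 36600 nM
- compound 2 `Cc1ccc(-n2nncc2CN2C(=O)C3(C(C#N)=C(N)Oc4c3c3nc5ccccc5nc3c3ccccc43)c3ccccc32)cc1C`: > 50000 nM, a limit of the assay
- compound 3 `COc1ccccc1-n1nncc1CN1C(=O)C2(C(C#N)=C(N)Oc3c(N)cc4nc5ccccc5nc4c32)c2ccccc21`: 28900 nM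

Compound 3 and compound 1 sit within the scatter of each other, so no order between them can be read. Compound 2 stands at the limit of > 50000 nM in this assay, at which 1 of the 3 values shown sits, and contributes no number.

The next compound is compound 4 `N#CC1=C(N)Oc2c(N)cc3nc4ccccc4nc3c2C12C(=O)N(Cc1cnnn1-c1cc(Cl)ccc1Cl)c1ccccc12`. Compared with compound 3 the change is 2,5-dichlorophenyl in place of 2-methoxyphenyl on an aromatic nitrogen.

Within the data shown here, the only measured step at the same position is the one from compound 1 to compound 2, an at least 1.3-fold higher number from compound 1 to compound 2 (0.13 log units; that floor lies within the scatter), which replaces one aryl group by another on the aromatic nitrogen and gives at most a change whose floor lies within the scatter, with the higher side open because of the limit. The exchange of 2-methoxyphenyl for 2,5-dichlorophenyl in compound 4 is a different pair of groups, so that step is only a loose guide. On this basis no step beyond the scatter is expected in this assay, in either direction, with some chance that compound 4 also reaches the limit.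

Compound 4 is expected at 32000 nM, with a range of 10000 nM to 100000 nM. The expected step is a 1.1-fold higher number from compound 3 to compound 4 (0.04 log units; within the scatter).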

Compound 4, half-maximal inhibitory concentration: 33200 nM
The estimate for compound 4 lay 1.0-fold (0.02 log units) below the measured number; the range from low to high includes it.
By their numbers in this assay, from the lowest: compounds 3, 4 and 1 (each within the scatter of the next). At a limit, above all of these: compound 2.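

In this assay, among these compounds, the exchange of 2-methoxyphenyl for 2,5-dichlorophenyl on the aromatic nitrogen gives a 1.1-fold higher number from compound 3 to compound 4 (0.06 log units; within the scatter), the first step at this position with a number at both ends. The two groups have the same heavy-atom count and differ in atoms and in hydrogen-bond acceptors: the leaving group counts one acceptor and the entering group none, and this exchange of oxygen-bearing for chlorine-bearing aryl leaves no change that can be read in this assay. On this core the two aryl groups cannot be told apart by this read-out, and no order between compound 3 and compound 4 can be read.

Compound 2 stays a limit and not a number: the limit of > 50000 nM in this assay, at which 1 of the 4 values shown sits.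

From the compounds shown here alone, whether a phenyl ring carrying a dimethylamino or carboxylic acid group, or a plain alkyl chain in place of the aryl ring on the aromatic nitrogen, would give a step beyond the scatter stays open.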